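Compound 2 to compound 4: methoxy to hydroxy

This account rests on a few compounds, and the source may have more. Where it says the series, first, only, none or still open, it means among the compounds named here.

In an ADME assay on KB cells (Homo sapiens) for cytotoxicity (a lower number here means that less compound is needed, a higher number that more compound is needed for the effect), compound 2 `COc1cc2c(c(OC)c1OC)C(=O)[C@]1(OC)C=C[C@H]2N(C(=O)OCC(C)C)N1C(=O)OCC(C)C` reads > 300 ug/mL, which is a limit of the assay and not a number. Compound 1 `CCOC(=O)N1[C@@H]2C=C[C@@](OC)(C(=O)c3c2cc(OC)c(OC)c3OCc2ccc(F)cc2)N1C(=O)OCC` gives 51.8 ug/mL, and compound 3 `CCCCOc1c(OC)c(OC)cc2c1C(=O)[C@]1(OC)C=C[C@H]2N(C(=O)OCC)N1C(=O)OCC` gives 76 ug/mL. Compound 4 `COc1cc2c(c(O)c1OC)C(=O)[C@]1(OC)C=C[C@H]2N(C(=O)OCC(C)C)N1C(=O)OCC(C)C` is reached through hydrogen in place of methyl on an oxygen on an aromatic ring. For the measured compounds named here, the only measured step that bears on this is a 1.5-fold higher number from compound 1 to compound 3 (0.17 log units; within the scatter), a change in the group on such an oxygen, and it offers no support for a large shift. The expected change is modest, towards a lower number, and is estimated as an at least 1.6-fold lower number from compound 2 to compound 4 (0.22 log units; that floor lies within the scatter). A second limit reading remains possible. For compound 4 the estimate is 180 ug/mL, with an expected range of 50 ug/mL to 450 ug/mL.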

Compound 4, concentration for half-maximal effect: > 300 ug/mL
Compound 4 gave a limit, no number; the forecaster's own chance of this, stated with the estimate: 40%; middle value at least 1.6-fold (0.22 log units) away from the limit.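

Compound 2 and compound 4 both give a limit of the assay and not a number, so no step between them can be read: the limit of > 300 ug/mL in this assay, at which 2 of the 4 values shown sit.

The compounds shown leave open whether methoxy to hydroxy shifts the read-out in this assay at all.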